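The source may hold more compounds than are shown below. What is called first, only, known or untested is meant among the compounds shown, and "the series" means these compounds.

Values in a functional assay on BXPC-3 cells (Homo sapiens) for antiproliferative activity, read by MTT assay, with a stated time of 24 h; on this read-out higher numbers stand for weaker inhibition and lower numbers for stronger inhibition:
- Compound 1 `CCn1c(C(=O)NCCNC(=O)OC(C)(C)C)ccc1C(CC)(CC)c1ccc(OCS(=O)(=O)c2ccccc2)c(C)c1`: > 50000 nM, a limit of the assay
- Compound 2 `CCn1c(C(=O)NC2(C(=O)O)CC2)ccc1C(CC)(CC)c1ccc(OCS(=O)(=O)c2ccccc2)c(C)c1`: > 50000 nM, a limit of the assay
- Compound 3 `CCn1c(C(=O)N[C@@H](C(=O)O)C(C)C)ccc1C(CC)(CC)c1ccc(OCS(=O)(=O)c2ccccc2)c(C)c1`: 13900 nM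

Compound 3 is the only one of the three with a number, 13900 nM, and the other two sit at the limit of > 50000 nM in this assay, at which 2 of the 3 values shown sit.

The next compound is compound 4 `CCn1c(C(=O)N[C@@H](CCC(=O)O)C(=O)O)ccc1C(CC)(CC)c1ccc(OCS(=O)(=O)c2ccccc2)c(C)c1`, which carries 1,3-dicarboxypropyl in place of 1-carboxy-2-methylpropyl on an amide-type nitrogen. For the measured compounds named here, two measured steps bear on this change, and both introduce the group that compound 4 gives up. They are an at least 3.5-fold lower number from compound 1 to compound 3 (0.55 log units; beyond the scatter) and an at least 3.5-fold lower number from compound 2 to compound 3 (0.55 log units; beyond the scatter). Both are at least modest and beyond the scatter, though their true size is hidden by the limits.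

Losing 1-carboxy-2-methylpropyl is therefore expected to move the number upward in this assay, possibly as far as the limit. Going by the values given here, no measured step tests 1,3-dicarboxypropyl itself, so this expectation is loose.

The expected change is a 2.2-fold higher number from compound 3 to compound 4 (0.33 log units; beyond the scatter). For compound 4 the estimated value is 30000 nM, with an expected range of 12000 nM to 50000 nM.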

Compound 4, half-maximal inhibitory concentration: > 50000 nM
Compound 4 was reported as a limit (the forecaster's own chance of this, stated with the estimate: 45%); at least 1.6-fold (0.22 log units) between middle value and limit.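

In this assay, putting 1,3-dicarboxypropyl in place of 1-carboxy-2-methylpropyl on the amide-type nitrogen gives an at least 3.5-fold higher number from compound 3 to compound 4 (0.55 log units; beyond the scatter), the first measured step away from compound 3 that starts from its number. Of the three compounds with a carboxy-bearing group at this place, compound 2, compound 3 and compound 4, only compound 3 gives a number, so a carboxy group there is not enough on its own to bring a value below the limit. The steps from compound 1 and compound 2 to compound 4 cannot be read, and compound 4 joins them at a limit rather than a number: the limit of > 50000 nM in this assay, at which 3 of the 4 values shown sit.

From the compounds shown here alone, how far compound 4 lies past that limit stays open. Also open, going by these compounds, is whether a methyl ester or a primary amide in place of the second carboxylic acid would restore a measurable number.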